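Swapping chloro for fluoro on a dicyano-free diaminoquinazoline core

This account rests on a few compounds, and the source may have more. Where it says the series, first, only, none or still open, it means among the compounds named here.

Compound 1 `N#Cc1c(F)c(Cl)c2nc(N)nc(N)c2c1F` gives 1.5 ug/mL in a functional assay on A-431 cells (Homo sapiens) for cytotoxicity, read by MTT assay; on this read-out lower numbers stand for stronger inhibition and higher numbers for weaker inhibition. Compound 2 `N#Cc1c(F)c(F)c2nc(N)nc(N)c2c1F` differs from it by fluoro in place of chloro on an aromatic carbon and gives 105 ug/mL; this is a 70-fold higher number from compound 1 to compound 2 (1.85 log units; beyond the scatter). Compound 3 `CC(C)(C)Nc1c(C#N)c(F)c2c(N)nc(N)nc2c1Cl` differs from compound 1 by (tert-butyl)amino in place of fluoro on an aromatic carbon. Compound 3 gives 6.5 ug/mL, a step of a 4.3-fold higher number from compound 1 to compound 3 (0.64 log units; beyond the scatter). Compound 4 `CC(C)(C)Nc1c(C#N)c(F)c2c(N)nc(N)nc2c1F` is not yet measured; it differs from compound 3 by fluoro in place of chloro on an aromatic carbon. This is the same kind of change as that from compound 1 to compound 2, though the place is ortho to a (tert-butyl)amino group rather than ortho to a fluoro group. Because a 70-fold higher number from compound 1 to compound 2 (1.85 log units; beyond the scatter) was large, the step from compound 3 to compound 4 is expected to be large as well, about a 15-fold higher number from compound 3 to compound 4 (1.19 log units; beyond the scatter). Compound 4 is therefore estimated at 100 ug/mL, expected between 30 ug/mL and 300 ug/mL.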

Compound 4, half-maximal inhibitory concentration: 11.9 ug/mL
Compound 4: middle estimate off by 8.4-fold (0.92 log units), on the high side; the measured number lies below the stated range.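

In this assay the exchange of chloro for fluoro does not carry over from one core to the other: the same change on two cores in this assay, a 70-fold higher number (1.85 log units; beyond the scatter) from compound 1 to compound 2 and a 1.8-fold higher number (0.26 log units; within the scatter) from compound 3 to compound 4, 38-fold (1.58 log units) apart, beyond the scatter of two such steps. The exchange of fluoro for (tert-butyl)amino does not carry over either, and its direction reverses: the same change on two cores in this assay, a 4.3-fold higher number (0.64 log units; beyond the scatter) from compound 1 to compound 3 and an 8.8-fold lower number (0.95 log units; beyond the scatter) from compound 2 to compound 4, 38-fold (1.58 log units) apart, beyond the scatter of two such steps. The new steps, a 1.8-fold higher number from compound 3 to compound 4 (0.26 log units; within the scatter) and an 8.8-fold lower number from compound 2 to compound 4 (0.95 log units; beyond the scatter), show that in these four compounds the outcome of each change depends on what else the core bears, but they do not show why, or how either change would behave on any other core.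

The compounds shown leave open whether a smaller amine, such as methylamino, would give the same dependence as (tert-butyl)amino. They also leave open how bromo would compare with chloro and fluoro on these cores.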